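The compounds below may be only part of what the source reports. "The series", "measured", "known", "first", "only" and "open" are said of these compounds alone.

Of the compounds shown here, three of one shared core have been measured in a functional assay on DLD-1 cells (Homo sapiens) for cytotoxicity, read by MTT assay, with a stated time of 48 h; on this read-out lower numbers stand for stronger inhibition and higher numbers for weaker inhibition. Compound 1, `CC(C)COc1ccc2c(Cl)ccnc2c1`, gives 3100 nM in this assay. Among the three numbers it stands second highest. Compound 2, `CCOc1ccc2c(NCCCN(C)C)ccnc2c1`, gives 8540 nM, the nearest number to compound 1 and a higher one, beyond the usual scatter. Compound 3, `CN(C)CCNc1ccnc2cc(OCc3ccc(F)cc3)ccc12`, gives 810 nM, the lowest of the three and the furthest from compound 1, again beyond the scatter.

Compound 4, `CC(C)Oc1ccc2c(Cl)ccnc2c1`, has not yet been measured in this assay. It differs from compound 1 in one place: isopropyl in place of isobutyl on an oxygen on an aromatic ring. The change removes one carbon from a short chain on the oxygen and keeps everything else of compound 1 unchanged. Among the measured compounds shown here, no pair of measured compounds shows such a step, so nothing in the data directly tells its size.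

Since the difference is so small, compound 4 is expected to land close to compound 1, with a step of a 1.1-fold higher number from compound 1 to compound 4 (0.05 log units; within the scatter) that does not go beyond the scatter. Compound 4 is therefore estimated at 3500 nM in this assay, within a range from 1500 nM to 8000 nM.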

Compound 4, half-maximal inhibitory concentration: 3240 nM
Compound 4: the middle estimate sits 1.1-fold (0.03 log units) above what was measured; the measured number falls inside the stated range.
By their numbers in this assay, from the lowest: compound 3; then compounds 1 and 4 (each within the scatter of the next); then compound 2.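

In this assay, isopropyl in place of isobutyl on an oxygen on an aromatic ring gives a 1.0-fold higher number from compound 1 to compound 4 (0.02 log units; within the scatter). Among the compounds shown here, this is the first step in the set that changes a single place, so the chain on the oxygen can now be read on its own, which the earlier compounds, differing from one another in more than one place, did not allow. On the core of compound 1, removing one carbon from this short chain leaves the number within the scatter, and nothing available offers an explanation for this.

On these data alone, whether the same holds for a longer chain such as octyl, or for a chain ending in a carboxylic acid or an amine, remains open. As far as these compounds go, it also remains open whether this step would look the same with the other parts of compound 2 or compound 3 in place.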